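From 4-Aminophenyl to 2-Aminophenyl on a Sulfur

This account rests on a few compounds, and the source may have more. Where it says the series, first, only, none or still open, it means among the compounds named here.

In an ADME assay on BHK15 cells (Mesocricetus auratus) for cytotoxicity, read by MTT assay, with a stated time of 36 h (on this read-out lower numbers stand for higher toxicity in this test and higher numbers for lower toxicity in this test), compound 3 `Nc1ccc(SCc2csc(-c3ccccc3Cl)n2)cc1` gives 131000 nM, within the scatter of compound 1 `Nc1ccc(SCc2csc(-c3ccc(Cl)cc3)n2)cc1` at 151000 nM and of compound 2 `Nc1ccccc1SCc1csc(-c2ccccc2)n1` at 119000 nM. Compound 4 `Nc1ccccc1SCc1csc(-c2ccccc2Cl)n1` differs from compound 3 by one change: 2-aminophenyl in place of 4-aminophenyl on a sulfur, with 2-aminophenyl in place of 4-aminophenyl on a sulfur. Among the compounds with values here, the one measured step, a 1.2-fold lower number from compound 1 to compound 3 (0.06 log units; within the scatter), stays within the scatter and concerns the chlorophenyl group, not the aminophenyl group. Within the data shown here, no measured step isolates the new change, but compound 2, which carries 2-aminophenyl, shows 119000 nM. No shift beyond the scatter is therefore expected, and the estimated step is a 1.0-fold lower number from compound 3 to compound 4 (0.02 log units; within the scatter). For compound 4 the expected value is 125000 nM, with an estimated range of 75000 nM to 200000 nM.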

Compound 4, half-maximal cytotoxic concentration: 133000 nM
Estimate against measurement, compound 4: 1.1-fold (0.03 log units) below; the range from low to high includes it.
By their numbers in this assay, from the lowest: compounds 2, 3, 4 and 1 (each within the scatter of the next).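

In this assay, within the data shown here, 2-aminophenyl in place of 4-aminophenyl on a sulfur gives a 1.0-fold higher number from compound 3 to compound 4 (0.01 log units; within the scatter) and so isolates this change, which the earlier compounds could not do. With 2-aminophenyl on the sulfur, chloro in place of hydrogen on an aromatic carbon gives a 1.1-fold higher number from compound 2 to compound 4 (0.05 log units; within the scatter) and so also leaves the number within the scatter. Nothing at hand explains these results. On these data alone, it remains open whether a carboxylic acid in place of the amino group would move the number beyond the scatter. A longer chain on the sulfur is equally untested among the compounds shown.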